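A few compounds are considered here, and "the series" means these few. Any claim that something is new, unique, unknown or untested is made for them only; others in the source may bear on it.

Compound 1: `Oc1ccc(-c2nc3ncccn3c2NC2CCCCC2)cc1` — > 100000 nM
Compound 2: `Oc1cccc(-c2nc3ncccn3c2NC2CCCCC2)c1` — 100000 nM

For the measured compounds named here, in a toxicity assay on A549 cells (Homo sapiens) for cytotoxicity, read by luminescence and CellTiter-Glo, with a stated time of 48 h (a higher number here means that more compound is tolerated, a lower number that less compound is tolerated), compound 2 gives 100000 nM, the only plain number among the two values shown. The value of compound 1, > 100000 nM, is a limit of the assay rather than a number. Compound 3 is `Oc1ccccc1-c1nc2ncccn2c1NC1CCCCC1`. It differs from compound 2 in one place: 2-hydroxyphenyl in place of 3-hydroxyphenyl on an aromatic carbon. The hydroxyl thus moves around the same ring while the rest of the shared core stays as it is. Going by the values given here, only one measured step bears on this change: a number no higher from compound 1 to compound 2 (the limit leaves the size open). That step gives no readable size because of the limit of > 100000 nM in this assay, at which 1 of the 2 values shown sits. Moving the hydroxyl once on this ring did not lower tolerance in any readable way, and both measured compounds sit at the top of what this assay reports. For compound 3 no step beyond the scatter is therefore expected, no change at the digits printed from compound 2 to compound 3 (within the scatter). Compound 3 is estimated at 100000 nM, with a range from 50000 nM to 200000 nM.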

Compound 3, half-maximal cytotoxic concentration: > 100000 nM
Compound 3: no number, only a limit; the forecaster's own chance of this, stated with the estimate: 50%; the middle value lies on the limit itself.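

With 2-hydroxyphenyl in place, all three hydroxyl placements on this ring have now been tested, and in this assay compound 3 gives > 100000 nM, which is a limit of the assay and not a number. The change is a number no lower from compound 2 to compound 3 (the limit leaves the size open), so moving the hydroxyl to this last placement brings no sign of lower tolerance. No step among these three compounds has a readable size, because of a shared limit: the limit of > 100000 nM in this assay, at which 2 of the 3 values shown sit.

As far as these compounds go, how far compound 1 and compound 3 lie past that limit remains open, so their order cannot be told. From the compounds shown here alone, it is also open whether an amine or a carboxylic acid on this ring in place of the hydroxyl, or a butyl chain in place of the cyclohexylamino group, would bring tolerance down into a readable range.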